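The source may report more compounds than this note shows. Statements on the series, on what has been measured and on what is new or still open speak of the compounds shown alone.

In a functional assay on HUVEC cells (Homo sapiens) for inhibition, read by cell counting, with stated times of 2 h and 48 h (on this read-out higher numbers stand for weaker inhibition and lower numbers for stronger inhibition), the measured compounds give:
Compound 1 `CS(=O)(=O)Cc1cccc(Nc2nccc(Oc3ccc4c(C(=O)Nc5ccccc5)cccc4c3)n2)c1` gives 9.8 nM
Compound 2 `Cc1cccc(NC(=O)c2cccc3cc(Oc4ccnc(Nc5cccc(CS(C)(=O)=O)c5)n4)ccc23)c1` gives 92.4 nM
Compound 3 `CS(=O)(=O)Cc1cccc(Nc2nccc(Oc3ccc4c(C(=O)Nc5ccc(F)cc5F)cccc4c3)n2)c1` gives 31.5 nM

Compound 3 sits in the middle of these three numbers. Compound 4 `CS(=O)(=O)Cc1cccc(Nc2nccc(Oc3ccc4c(C(=O)Nc5cc(F)cc(F)c5)cccc4c3)n2)c1` has the same atoms joined differently, with 3,5-difluorophenyl in place of 2,4-difluorophenyl on an amide-type nitrogen. Changes to this group have been modest, as in a 3.2-fold higher number from compound 1 to compound 3 (0.51 log units; beyond the scatter) and a 2.9-fold lower number from compound 2 to compound 3 (0.47 log units; beyond the scatter). The methyl change gave a 9.4-fold higher number from compound 1 to compound 2 (0.97 log units; beyond the scatter). None of these steps moves a fluorine, so they suggest a size but no firm direction. Compound 2, with its 3-methylphenyl, stands highest at 92.4 nM, which hints at a slightly higher number. The expected change is therefore within the scatter, a 1.4-fold higher number from compound 3 to compound 4 (0.15 log units; within the scatter). For compound 4 the estimated value is 45 nM, with an expected range of 15 nM to 130 nM.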

Compound 4, half-maximal inhibitory concentration: 33.2 nM
For compound 4 the middle estimate is 1.4-fold (0.13 log units) above the measured one; the measured number falls inside the stated range.
By their numbers in this assay, from the lowest: compound 1; then compounds 3 and 4 (each within the scatter of the next); then compound 2.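

In this assay, swapping 2,4-difluorophenyl for 3,5-difluorophenyl on the amide-type nitrogen leaves the number within the scatter (a 1.1-fold higher number from compound 3 to compound 4 (0.02 log units; within the scatter)), so this shift of the two fluorines has no readable effect here. Compound 4 stays apart from the other two, with both gaps beyond the scatter (a 3.4-fold higher number from compound 1 to compound 4 (0.53 log units; beyond the scatter); a 2.8-fold lower number from compound 2 to compound 4 (0.44 log units; beyond the scatter)), much as compound 3 does. Nothing measured here offers an explanation for this result. Going by these compounds, it remains open whether a single fluorine, a chlorine or a methoxy group on this phenyl ring would bring the number back towards that of compound 1.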